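Notes on uracil nucleotide agonists at the purinoceptor

This account rests on a few compounds, and the source may have more. Where it says the series, first, only, none or still open, it means among the compounds named here.

Compound 1 `CCCc1cc(=O)n([C@@H]2O[C@H](COP(=O)(O)OP(=O)(O)OP(=O)(O)O)[C@@H](O)[C@H]2O)c(=O)[nH]1`: > 100000 nM
Compound 2 `Cn1c(=O)ccn([C@@H]2O[C@H](COP(=O)(O)OP(=O)(O)O)[C@@H](O)[C@H]2O)c1=O`: > 1000 nM
Compound 3 `O=c1[nH]c(=O)n([C@@H]2O[C@H](COP(=O)(O)OP(=O)(O)O)[C@@H](O)[C@H]2O)cc1Br`: 151 nM

In an in vitro functional assay on 1321-N1 cells for agonist activity at P2Y purinoceptor 6 (Homo sapiens) (a higher number here means that more compound is needed for the effect, a lower number that less compound is needed), compound 1 gives only a limit, > 100000 nM, not a number. Compound 2 also returns a limit, > 1000 nM. Compound 3 gives 151 nM. Compound 1 therefore stands at the limit end of the three values, and one further value is likewise a limit (the limit of > 100000 nM in this assay, at which 1 of the 3 values shown sits, (the limit of > 1000 nM in this assay, at which 1 of the 3 values shown sits)).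

Compound 4 `CCCc1cc(=O)n([C@@H]2O[C@H](COP(=O)(O)OP(=O)(O)O)[C@@H](O)[C@H]2O)c(=O)[nH]1` differs from compound 1 by a hydrogen atom in place of a group of 4 heavy atoms (3 oxygen, 1 phosphorus; no ring), on an oxygen. Among the compounds with values here, no measured pair shows this change, so its size in this assay is not known; with compound 1 at a limit, only a step toward less compound needed could be seen at all, and a clear one is expected. Compound 4 is estimated at 5000 nM, within 500 nM to 50000 nM, an expected step of an at least 20-fold lower number from compound 1 to compound 4 (1.30 log units; beyond the scatter).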

Compound 4, half-maximal effective concentration: > 1000 nM
Compound 4 ended at the assay's limit; the forecaster's own chance of this, stated with the estimate: 35%; the middle value is on the limit's open side.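

Within the data shown here, compound 1 and compound 4 both stand at limits in this assay, and no step between them can be read. The compounds shown leave open whether the hydrogen in place of the group of 4 heavy atoms (3 oxygen, 1 phosphorus; no ring) changes the effect at all.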